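A few compounds are considered here, and "the series" means these few. Any claim that something is new, unique, unknown or untested is made for them only; others in the source may bear on it.

For the measured compounds named here, compound 2 `O=C(CN1CCN(c2ccc(Cl)cc2)CC1)N1CCN(c2nnc(-c3ccccc3)c(-c3ccccc3)n2)CC1` gives 113000 nM in an ADME assay on NIH3T3 cells (Mus musculus) for cytotoxicity, read by MTT assay, with a stated time of 24 h (a lower number here means a stronger inhibitor, a higher number a weaker inhibitor), the lowest of the two numbers measured so far; compound 1 `O=C(CN1CCN(c2ccccc2Cl)CC1)N1CCN(c2nnc(-c3ccccc3)c(-c3ccccc3)n2)CC1` gives 350000 nM, and the step of a 3.1-fold lower number from compound 1 to compound 2 (0.49 log units; beyond the scatter) is the only measured step on this core. Compound 3 `O=C(CN1CCN(c2ccc([N+](=O)[O-])cc2)CC1)N1CCN(c2nnc(-c3ccccc3)c(-c3ccccc3)n2)CC1` carries nitro in place of chloro on an aromatic carbon. The measured step moves a chloro to another position on the same ring and does not exchange it for another group, so it bears only loosely on this change. Compound 3 is therefore expected to show no step beyond the scatter, a 1.1-fold higher number from compound 2 to compound 3 (0.03 log units; within the scatter). The estimate for compound 3 in this assay is 120000 nM, ranging from 40000 nM to 400000 nM.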

Compound 3, half-maximal inhibitory concentration: > 886000 nM
Compound 3 ended at the assay's limit; the forecaster's own chance of this, stated with the estimate: 10%; middle value at least 7.3-fold (0.86 log units) away from the limit.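

Compound 3 reads as a limit of the assay and not as a number: the limit of > 886000 nM in this assay, at which 1 of the 3 values shown sits. Even so, nitro in place of chloro on this aromatic carbon gives an at least 7.8-fold higher number from compound 2 to compound 3 (0.89 log units; beyond the scatter), which shows that the group at this place moves the number in this assay, whereas the earlier step only moved a chloro around the ring. The 4-nitrophenyl also clears the 2-chlorophenyl, with an at least 2.5-fold higher number from compound 1 to compound 3 (0.40 log units; beyond the scatter). From the compounds shown here alone, the true size of both steps remains open. So does how an amine or a methoxy group on this carbon would read in this assay.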